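Two Chlorophenyl Amides Compared Before Measurement

The source may hold more compounds than are shown below. What is called first, only, known or untested is meant among the compounds shown, and "the series" means these compounds.

Of the compounds shown here, three sharing one core have been tested in a functional assay on U-251 cells (Homo sapiens) for antiproliferative activity, read by MTT assay, with a stated time of 72 h; a lower number here means a stronger inhibitor, a higher number a weaker inhibitor. Compound 1 `O=C(Nc1ccc(Cl)c(-c2nnc3c(Cl)cccn23)c1)c1cccnc1` carries a pyridin-3-yl on the carbonyl carbon, compound 2 `O=C(Nc1ccc(Cl)c(-c2nnc3c(Cl)cccn23)c1)c1ccc(Cl)cc1` a 4-chlorophenyl, and compound 3 `O=C(Nc1ccc(Cl)c(-c2nnc3c(Cl)cccn23)c1)c1cccnc1Cl` a 2-chloropyridin-3-yl. In this assay compound 1 gives > 100000 nM, a limit of the assay rather than a number. Compound 2 likewise gives > 100000 nM, again only a limit. Compound 3 too gives > 100000 nM, also a limit. Because (the limit of > 100000 nM in this assay, at which 3 of the 3 values shown sit), every step among them is unreadable: a step that the two limits leave unreadable from compound 1 to compound 2, a step that the two limits leave unreadable from compound 1 to compound 3 and a step that the two limits leave unreadable from compound 2 to compound 3.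

Compound 4 `O=C(Nc1ccc(Cl)c(-c2nnc3c(Cl)cccn23)c1)c1ccccc1Cl` is not yet measured. It differs from compound 2 in one place: 2-chlorophenyl in place of 4-chlorophenyl on a carbonyl carbon. Going by the values given here, no measured step shows how moving the chlorine within a chlorophenyl on the carbonyl carbon changes the read-out, and the three limits give no scale for any step at all. Among the compounds with values here, the only guide is that compound 2 itself sits at the limit, so compound 4 is expected to sit there as well, an estimated step that the limit leaves unreadable from compound 2 to compound 4. Compound 4 is therefore estimated at 150000 nM, with a range from 40000 nM to 600000 nM, most likely reported as a limit.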

Compound 4, half-maximal inhibitory concentration: > 100000 nM
Compound 4 gave a limit, no number; the forecaster's own chance of this, stated with the estimate: 85%; the middle value does not contradict the limit.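

In this assay compound 4 gives > 100000 nM, which is a limit and not a number. None of the steps linking compound 4 to compound 1, compound 2 or compound 3 can be read, because all four compounds share one limit: the limit of > 100000 nM in this assay, at which 4 of the 4 values shown sit.

The compounds shown leave open whether any group on the carbonyl carbon of the shared core gives a measurable value.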